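The source may report more compounds than this note shows. Statements on the series, on what has been measured and on what is new or still open speak of the compounds shown alone.

Three compounds have been measured in an assay on HEK293 cells for positive allosteric modulation of metabotropic glutamate receptor 5 (Homo sapiens), read by FLIPR, with a stated time of 1 h (on this read-out lower numbers stand for an effect already at smaller amounts and higher numbers for an effect only at larger amounts of compound), and each of them gave only a limit of the assay:

compound 1 `CN1CCc2nc(C#Cc3cccc(F)c3)sc2C1`: > 10000 nM
compound 2 `CC(C)CN1CCc2nc(C#Cc3ccccc3)sc2C1`: > 10000 nM
compound 3 `Fc1cccc(C#Cc2nc3c(s2)CN(C2CCC2)CC3)c1`: > 10000 nM

Compound 2 therefore stands at the limit of > 10000 nM in this assay, at which 3 of the 3 values shown sit, and nothing separates it from the other two. Compound 4 `O=C(C1CCCO1)N1CCc2nc(C#Cc3ccccc3)sc2C1` differs from it by (oxolan-2-yl)carbonyl in place of isobutyl on an amine nitrogen in a ring. Within the data shown here, the only step between measured compounds that changes the same position is a step that the two limits leave unreadable from compound 1 to compound 3, whose size is hidden by the two limits, so it gives no direction or size to expect for the new change. Compound 4 is thus expected to sit at about 15000 nM, with a range from 3000 nM to 80000 nM. The expected step is a step that the limit leaves unreadable from compound 2 to compound 4.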

Compound 4, half-maximal effective concentration: 790 nM
Compound 4: the middle estimate sits 19-fold (1.28 log units) above what was measured; measured number below the stated range.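

In this assay, the amine nitrogen in a ring proves to be a position where a change can be read: (oxolan-2-yl)carbonyl in place of isobutyl gives an at least 12-fold lower number from compound 2 to compound 4 (1.10 log units; beyond the scatter). Among these compounds, the earlier step at this nitrogen could not be read, so this is the first change there with a visible direction. Compound 4 alone gives a number rather than a limit: the limit of > 10000 nM in this assay, at which 3 of the 4 values shown sit.

As far as these compounds go, the change brings in the carbonyl and the oxolan-2-yl ring together, so which of them matters stays open. An acetyl or a cyclopentylcarbonyl on the same nitrogen would separate the two.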